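Methyl for chloro on the pyridine of compound 1

The compounds below may be only part of what the source reports. "The series", "measured", "known", "first", "only" and "open" are said of these compounds alone.

For the measured compounds named here, compound 1, whose structure is `C[C@@H]1CN(c2ncccc2Cl)CCN1c1nc2ccc(C(C)(C)C)cc2[nH]1`, is the only compound here with a numerical result: in a functional assay on HEK293 cells for antagonist activity at transient receptor potential cation channel subfamily V member 1 (Homo sapiens), read by FLIPR, at pH 5.5 (on this read-out lower numbers stand for stronger inhibition and higher numbers for weaker inhibition), compound 1 gives 104 nM. Compound 2, with structure `Cc1cc2nc(N3CCN(c4ncccc4Cl)C[C@@H]3C)[nH]c2cc1C`, carries a different core, and in this assay compound 2 reaches only the limit > 25000 nM, which is a boundary of the measurement rather than a number; that is the point described by the limit of > 25000 nM in this assay, at which 1 of the 2 values shown sits. Going by the values given here, compound 2 differs from compound 1 in more than one place, so the two results show only that one compound is measured and the other is not.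

Compound 3, with structure `Cc1cccnc1N1CCN(c2nc3ccc(C(C)(C)C)cc3[nH]2)[C@H](C)C1`, is the unmeasured partner of compound 1. The change is methyl in place of chloro on an aromatic carbon, ortho to a large group and two atoms from the ring nitrogen, so that 3-chloropyridin-2-yl becomes 3-methylpyridin-2-yl. Among the compounds with values here, no measured pair shows this exchange here, so the expectation rests on the exchange itself. For compound 3 the expected outcome in this assay is 200 nM, within an estimated range from 60 nM to 700 nM. The step this implies, a 1.9-fold higher number from compound 1 to compound 3 (0.28 log units; within the scatter), is expected to stay within or just beyond the scatter, with weakening judged somewhat more likely than gain.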

Compound 3, half-maximal inhibitory concentration: 597 nM
Beside the measured number, compound 3's estimate is 3.0-fold (0.47 log units) below it; the measured number falls inside the stated range.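

For the compounds shown here, the exchange of 3-chloropyridin-2-yl for 3-methylpyridin-2-yl provides the first readable step in this set: in this assay it gives a 5.7-fold higher number from compound 1 to compound 3 (0.76 log units; beyond the scatter), so on this aromatic carbon, ortho to a large group and two atoms from the ring nitrogen, methyl and chloro are not interchangeable. The two groups match in every count computed for them, with 1 heavy atom each, no ring, no hydrogen-bond donors or acceptors and no net charge, so those counts do not separate them even though the step lies beyond the scatter. No measurement given here bears on why the step has this size.

A single exchange at one position leaves open how other groups on this carbon, such as fluoro, methoxy or nitrile, would compare with chloro and methyl in this assay. It also leaves open whether the exchange would have a similar effect on a different core, and compound 2 cannot help here, since its result is only a limit and it carries chloro rather than methyl.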